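This account rests on a few compounds, and the source may have more. Where it says the series, first, only, none or still open, it means among the compounds named here.

Measured so far:
compound 1, `O=C(CSC(=S)N[C@H]1CCOC1=O)Nc1ccccc1F`: 28600 nM
compound 2, `Cc1cccc(NC(=O)CSC(=S)N[C@H]2CCOC2=O)c1C`: > 128000 nM

Among the measured compounds shown here, in a functional assay on MCF7 cells (Homo sapiens) for cytotoxicity, read by MTT assay, with a stated time of 72 h (on this read-out lower numbers stand for stronger inhibition and higher numbers for weaker inhibition), compound 1 gives 28600 nM, the only proper number among the values shown. Compound 2 yields a limit of the assay rather than a number, > 128000 nM, and thus sits at the limit of > 128000 nM in this assay, at which 1 of the 2 values shown sits. For the measured compounds named here, the two values therefore show only that compound 1 was resolved within the range of this assay while compound 2 was not; no step between them can be sized.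

Compound 3, `O=C(CSC(=S)N[C@H]1CCOC1=O)Nc1ccc(F)cc1`, has yet to be measured in this assay. It differs from compound 1 by 4-fluorophenyl in place of 2-fluorophenyl on an amide-type nitrogen. Going by the values given here, no measured pair carries a change of this kind, so the data give no direction for it. The expected step of a 1.2-fold higher number from compound 1 to compound 3 (0.09 log units; within the scatter) is none beyond the scatter, with a wide range of uncertainty. Compound 3 is estimated at 35000 nM, with a range from 10000 nM to 120000 nM.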

Compound 3, half-maximal inhibitory concentration: 5830 nM
For compound 3 the middle estimate is 6.0-fold (0.78 log units) above the measured one; the whole stated range lies above it.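

In this assay, 4-fluorophenyl in place of 2-fluorophenyl on an amide-type nitrogen brings a 4.9-fold lower number from compound 1 to compound 3 (0.69 log units; beyond the scatter). Among the compounds shown here, this is the first step that can be sized, and it comes from a change that leaves the atoms of the group the same, so the read-out at this position depends on where the fluorine sits on the phenyl and not only on which atoms the group holds. No measurement shown accounts for this step, which so far rests on this single pair.

From the compounds shown here alone, it remains open whether unsubstituted phenyl would fall on either side of these two compounds. Going by these compounds, it is also open whether chlorine or a methoxy group in place of the fluorine would give a step of similar size.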